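The source may hold more compounds than are shown below. What is called first, only, known or untested is meant among the compounds shown, and "the series" means these compounds.

Measured so far in an assay for inhibition of mitogen-activated protein kinase kinase kinase 14 (Homo sapiens), read by luminescence and ADP-Glo, with a stated time of 120 min, in the presence of a further agent that is not named here; a higher number here means a weaker inhibitor, a lower number a stronger inhibitor:
compound 1 `CN(C)CCN(C)c1ccc(C#CC(C)(O)c2nccs2)cc1Nc1ncnc2[nH]ccc12` gives 484 nM
compound 2 `C[C@H]1CN(c2ccc(C#CC(C)(O)c3nccs3)cc2Nc2ncnc3[nH]ccc23)CCN1` gives 69.2 nM

Among the compounds with values here, compound 2 holds the lower of the two numbers; the single measured step, a 7.0-fold lower number from compound 1 to compound 2 (0.84 log units; beyond the scatter), sets it apart from compound 1. Compound 3 `CC(O)(C#Cc1ccc(N2CC3CC2CN3)c(Nc2ncnc3[nH]ccc23)c1)c1nccs1` carries a group of 7 heavy atoms (5 carbon, 2 nitrogen; 2 five-membered non-aromatic rings with 1 hetero atom each) in place of a group of 7 heavy atoms (5 carbon, 2 nitrogen; one six-membered non-aromatic ring with 2 hetero atoms), on an aromatic carbon. Within the data shown here, the measured step swapped an open chain for a ring group, whereas the move to compound 3 exchanges one ring group for another matching it in what is counted, so no measured step bears on it directly. For compound 3 the expected step in this assay is a 1.0-fold higher number from compound 2 to compound 3 (0.00 log units; within the scatter), not beyond the scatter. Compound 3 is therefore expected near 70 nM, within 25 nM to 200 nM.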

Compound 3, half-maximal inhibitory concentration: 200 nM
The estimate for compound 3 lay 2.9-fold (0.46 log units) below the measured number, within the range that was stated.
By their numbers in this assay, from the lowest: compound 2; then compound 3; then compound 1.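

At this aromatic carbon, para to the 3-hydroxy-3-(1,3-thiazol-2-yl)but-1-yn-1-yl group, two ring groups that match in heavy atoms, donors, acceptors and charge are not interchangeable in this assay (a 2.9-fold higher number from compound 2 to compound 3 (0.46 log units; beyond the scatter)). Within the data shown here, a ring group with 2 five-membered non-aromatic rings still differs from the open chain (a 2.4-fold lower number from compound 1 to compound 3 (0.38 log units; beyond the scatter)), so the 3-methylpiperazin-1-yl is not the only ring group here to give a lower number than that chain. No evidence accounts for the gap between the two ring groups.

From the compounds shown here alone, an unsubstituted piperazine or a morpholine at this carbon remains open. So does the contribution of the methyl group and its defined stereocentre to the number for compound 2.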